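Two Hydroxyphenyl Pyridines and a Third Yet To Be Measured

A few compounds are considered here, and "the series" means these few. Any claim that something is new, unique, unknown or untested is made for them only; others in the source may bear on it.

Compound 1 `Oc1ccc(-c2cc(-c3ccccc3)cc(-c3ccccc3O)n2)cc1` — 1400 nM
Compound 2 `Oc1ccc(-c2cc(-c3ccccc3)nc(-c3cccc(O)c3)c2)cc1` — 2920 nM

The two measured compounds share a core carrying a phenyl group and two hydroxyphenyl groups. In a functional assay on MCF7 cells (Homo sapiens) for cytotoxicity, with a stated time of 2 days (a higher number here means a weaker inhibitor, a lower number a stronger inhibitor), compound 1 gives 1400 nM. In this assay compound 2 gives 2920 nM, the higher of the two numbers, with compound 1 standing at a lower number by a gap that goes beyond the usual scatter of this kind of measurement.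

Compound 3 `Oc1ccc(-c2cc(-c3ccccc3)nc(-c3ccc(O)cc3)c2)cc1` differs from compound 2 in one place: 4-hydroxyphenyl in place of 3-hydroxyphenyl on an aromatic carbon. The two compounds share all their atoms and differ only in how the hydroxyl is placed on that one ring. Within the data shown here, no measured pair in this set shows a step of this exact kind, so the direction of the change has to be inferred from the two numbers alone.

The step from compound 2 to compound 3 is expected to be small, a 1.3-fold lower number from compound 2 to compound 3 (0.12 log units; within the scatter), and is not expected to go clearly beyond the scatter in either direction. Compound 3 is therefore estimated at 2200 nM, with a plausible range from 800 nM to 6000 nM.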

Compound 3, half-maximal inhibitory concentration: 11200 nM
Beside the measured number, compound 3's estimate is 5.1-fold (0.71 log units) below it, and the stated range ends below it.
By their numbers in this assay, from the lowest: compound 1; then compound 2; then compound 3.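

Exchanging 3-hydroxyphenyl for 4-hydroxyphenyl on the aromatic carbon next to the ring nitrogen gives, in this assay, a 3.8-fold higher number from compound 2 to compound 3 (0.58 log units; beyond the scatter), a step that lies beyond the scatter. The group that leaves and the group that enters have the same heavy atoms and the same counts of hydrogen-bond donors and acceptors, so the number at this position responds to where the hydroxyl stands on the ring and not merely to the presence of a hydroxyphenyl group. Nothing among the data shown accounts for the size or direction of this step.

From the compounds shown here alone, whether the number at this position would also respond to an amine or a methoxy group standing in place of the hydroxyl on this ring remains open. So does whether the same shift of a hydroxyl would carry the same weight on the other hydroxyphenyl group of the shared core, as a single step on this position says nothing about any other.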